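Methyl on the Pyrazole Nitrogen Across Two Related Cores

This account rests on a few compounds, and the source may have more. Where it says the series, first, only, none or still open, it means among the compounds named here.

Of the compounds shown here, three have been measured in an assay on isolated protein for inhibition of protein kinase C zeta type (Homo sapiens), read by mobility shift assay, tested at 30 uM; on this read-out lower numbers stand for less inhibition and higher numbers for more inhibition at the one concentration tested (going by the name of the read-out). Compound 1 `Cc1cc2[nH]nc(N)c2c(=O)[nH]1` carries a carbonyl on its core, and in this assay compound 1 gives 10%. Compound 3 `Cc1cc2c(c(N)nn2C)c(=O)[nH]1` is compound 1 after one change, (methyl in place of hydrogen on an aromatic nitrogen). In this assay compound 3 gives 0%, and the step of a number 10 percentage points lower from compound 1 to compound 3 (within the scatter) does not separate the two compounds in a meaningful way. Compound 2 `Cc1cc2[nH]nc(N)c2c(N2CCCCC2)n1` rests on a different core; how the two cores differ is not broken down here. In this assay compound 2 gives 43%, the highest of the three numbers and beyond the scatter from both compound 1 and compound 3.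

Compound 4 `Cc1cc2c(c(N)nn2C)c(N2CCCCC2)n1` has not been measured yet. Among the compounds with values here, it differs from compound 2 by methyl in place of hydrogen on an aromatic nitrogen, which is the same change as the one from compound 1 to compound 3, at the same kind of place on the five-membered ring. Within the data shown here, the only earlier instance of this change gave a small step, a number 10 percentage points lower from compound 1 to compound 3 (within the scatter), well within the ordinary scatter of repeated measurements. For compound 4 the expected step is a number 10 percentage points lower from compound 2 to compound 4 (within the scatter), resting on that single earlier instance where a number 10 percentage points lower from compound 1 to compound 3 (within the scatter) stayed within the scatter. Compound 4 is therefore expected to give about 33% in this assay, most likely between 12% and 55%; one precedent on a different core is thin ground, so the range is kept wide.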

Compound 4, a percentage reported as inhibition, at one concentration (the size of the read-out at that concentration, not a potency): -152%
Beside the measured number, compound 4's estimate is 185 percentage points above it; the measured number lies below the stated range.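

In this assay, methyl in place of hydrogen on an aromatic nitrogen did not behave the same way on the two cores: the same change on two cores in this assay, a number 10 percentage points lower (within the scatter) from compound 1 to compound 3 and a number 195 percentage points lower (beyond the scatter) from compound 2 to compound 4, 185 percentage points apart, beyond the scatter of two such steps. The step of a number 195 percentage points lower from compound 2 to compound 4 (beyond the scatter) therefore shows that the small step seen on the core of compound 1 gives no safe guide to the size of the same change on the core of compound 2, even though the methyl sits at the same kind of place on the five-membered ring. Within the data shown here, it does not show why the two steps differ or set a rule for other cores, since this is only two pairs of compounds, each read at one concentration, and compound 4 gives -152%, a number below zero on a read-out of inhibition that these data do not explain and that is not a potency.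

The compounds shown leave open which feature of the core of compound 2 goes with the large step, and whether an ethyl group or a longer chain on the same aromatic nitrogen would follow methyl. They also leave open whether a repeat reading, or readings at other concentrations, would give a step of similar size.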